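Working notes: phenyl to (oxolan-3-yl)oxy on the carbonyl carbon

This account rests on a few compounds, and the source may have more. Where it says the series, first, only, none or still open, it means among the compounds named here.

- compound 1 `Cc1cc(C(=O)NCc2ccccn2)nn1Cc1cc(Cl)ccc1OCc1ccccc1` gives 1.3 h
- compound 2 `Cc1cc(NC(=O)c2ccccc2)nn1Cc1cc(Cl)ccc1OCc1ccccc1` gives 2.5 h

Compound 2 stands within the scatter of compound 1 in an in vivo ADME assay on the whole organism for metabolic stability, with Rattus norvegicus as the target (a lower number here means that the compound disappears faster, a higher number that the compound lasts longer), and the two are not separated. The difference (oxolan-3-yl)oxy in place of phenyl on a carbonyl carbon leads from compound 2 to compound 3 `Cc1cc(NC(=O)O[C@H]2CCOC2)nn1Cc1cc(Cl)ccc1OCc1ccccc1` and puts (oxolan-3-yl)oxy in place of phenyl on a carbonyl carbon. Going by the values given here, the one measured step of a 1.9-fold higher number from compound 1 to compound 2 (0.28 log units; within the scatter) stays within the scatter and does not test this replacement, so no step beyond the scatter is expected in either direction. The estimated step is a 1.3-fold lower number from compound 2 to compound 3 (0.10 log units; within the scatter) on that expectation. The estimate for compound 3 is 2 h and the expected range runs from 0.9 h to 4.5 h at this stage.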

Compound 3, half-life: 0.8 h
Compound 3: middle estimate off by 2.5-fold (0.40 log units), on the high side; the measured number lies below the stated range.
By their numbers in this assay, from the lowest: compounds 3, 1 and 2 (each within the scatter of the next, the first and the last beyond it).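

In this assay, going by these compounds alone, (oxolan-3-yl)oxy in place of phenyl on a carbonyl carbon gives a 3.1-fold lower number from compound 2 to compound 3 (0.49 log units; beyond the scatter), the only step so far that lies beyond the scatter, so this place does respond to a change of group. The other new step, a 1.6-fold lower number from compound 1 to compound 3 (0.21 log units; within the scatter), lies within the scatter and does not separate these two compounds. Nothing measured here accounts for the shorter half-life of compound 3.

The compounds shown leave open whether the ring or the linking oxygen of (oxolan-3-yl)oxy matters for this step, and what an open-chain ethoxy group or an amine on the same carbonyl carbon would give.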